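The source may report more compounds than this note shows. Statements on the series, on what has been measured and on what is new or still open speak of the compounds shown alone.

Of the compounds shown here, three built on one shared core have been tested in an assay on HEK293 cells for inhibition of Voltage-dependent T-type calcium channel subunit alpha-1G (Homo sapiens), read by fluorescence, tested at 10 uM; on this read-out higher numbers stand for more inhibition at the one concentration tested (going by the name of the read-out) and lower numbers for less inhibition. Compound 1 `CCCc1nc(-c2ccccc2)c(CNCCN2CCN(c3ccc(Cl)cc3)CC2)o1` gives 55.8%. Compound 2 `CCCc1nc(-c2ccccc2)c(CNCCCN2CCN(c3cccc(OC)c3)CC2)o1` gives 36.4% in this assay, and compound 3 `CCCc1nc(-c2ccccc2)c(CNCCCN2CCN(c3ccc(C)cc3)CC2)o1` gives 53.9%. Compound 1 has the highest number of the three, but compound 3 sits within the usual scatter of it, so these two cannot be told apart; compound 2 sits beyond the scatter. For the measured compounds named here, the one measured step between close neighbours is a number 17.5 percentage points higher from compound 2 to compound 3 (beyond the scatter), a change of the aromatic group on the ring nitrogen.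

Compound 4 `CCCc1nc(-c2ccccc2)c(CNCCN2CCN(c3ccccn3)CC2)o1` has not yet been measured in this assay. It differs from compound 1 by pyridin-2-yl in place of 4-chlorophenyl on an amine nitrogen in a ring. Going by the values given here, no measured step exchanges a six-membered aromatic ring of carbon only for a ring with a hetero atom, so the direction is uncertain; the step from compound 2 to compound 3 only shows how far a change of that group has moved the read-out. Compound 4 is therefore expected to give 40%, between 20% and 60%. The expected step is a number 15.8 percentage points lower from compound 1 to compound 4 (beyond the scatter), a modest fall, judged against the size of a number 17.5 percentage points higher from compound 2 to compound 3 (beyond the scatter).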

Compound 4, a percentage reported as inhibition, at one concentration (the size of the read-out at that concentration, not a potency): 48.1%
The estimate for compound 4 lay 8.1 percentage points below the measured number, and the stated range covers the measured number.
By their numbers in this assay, from the lowest: compound 2; then compounds 4, 3 and 1 (each within the scatter of the next).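

In this assay, pyridin-2-yl in place of 4-chlorophenyl on the amine nitrogen in a ring gives a number 7.7 percentage points lower from compound 1 to compound 4 (within the scatter) and so leaves the two compounds indistinguishable, even though a chlorine leaves and a ring with a hetero atom and a hydrogen-bond acceptor enters. A change of the aromatic group on this nitrogen therefore need not move the number beyond the scatter, although the earlier step of a number 17.5 percentage points higher from compound 2 to compound 3 (beyond the scatter) did so on a longer chain. Nothing given here explains why this exchange leaves the read-out within the scatter.

From the compounds shown here alone, whether plain phenyl, pyridin-4-yl or a non-aromatic cyclohexyl group would read the same on this nitrogen remains open. So does whether pyridin-2-yl would behave the same way on the longer chain of compound 2 and compound 3.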